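Aryl halogen swap on a sulfur-containing five-membered ring

This account rests on a few compounds, and the source may have more. Where it says the series, first, only, none or still open, it means among the compounds named here.

Three compounds share a core in which a five-membered aromatic ring with one sulfur carries an amino group and a (4-chlorophenyl)carbonyl group. Compound 1 `CC(C)(C)c1csc(N)c1C(=O)c1ccc(Cl)cc1` has a tert-butyl group on the ring, compound 2 `Cc1c(Br)sc(N)c1C(=O)c1ccc(Cl)cc1` a methyl and a bromine, and compound 3 `CC(C)(C)Cc1c(-c2cccc(F)c2F)sc(N)c1C(=O)c1ccc(Cl)cc1` a neopentyl group and a 2,3-difluorophenyl. In an assay on CHO cells for displacement of a labelled ligand from adenosine receptor A1 (Homo sapiens), read by scintillation counting, tested at 10 uM (a higher number here means more inhibition at the concentration tested (going by the name of the read-out), a lower number less inhibition), compound 1 gives 1%, compound 2 gives 1%, and compound 3 gives 1%. On these numbers compound 3 stands level with compound 1 and compound 2 within the scatter; none of the three shows meaningful displacement.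

Compound 4 `CC(C)(C)Cc1c(-c2ccc(Cl)c(Cl)c2)sc(N)c1C(=O)c1ccc(Cl)cc1` has not been measured in this assay. It differs from compound 3 by 3,4-dichlorophenyl in place of 2,3-difluorophenyl on an aromatic carbon, the change sitting next to the ring sulfur and next to the ring atom that bears the neopentyl group. Among the measured compounds shown here, no pair of measured compounds isolates this change. Because compound 3 gives 1% and the other halogenated analogues sit at the same level, compound 4 is expected to show no step beyond the scatter. The expected step of a number 1 percentage points higher from compound 3 to compound 4 (within the scatter) is accordingly estimated as none beyond the scatter. Compound 4 is expected to give 2%, within a range from -6% to 12%.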

Compound 4, a percentage reported as inhibition, at one concentration (the size of the read-out at that concentration, not a potency): 1%
The estimate for compound 4 lay 1 percentage points above the measured number, and the stated range covers the measured number.
By their numbers in this assay, from the lowest: compounds 1, 2, 3 and 4 (each within the scatter of the next).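

Among the compounds shown here, the swap of 2,3-difluorophenyl for 3,4-dichlorophenyl, on an aromatic carbon next to the ring sulfur and next to the ring atom that bears a neopentyl group, is the first change in this set that can be read in a single place, and in this assay it gives no change at the digits printed from compound 3 to compound 4 (within the scatter) as its step. The earlier compounds shown here differ in more than one place and could not show this, whereas here two fluorine atoms give way to two chlorine atoms on the phenyl ring with the count of heavy atoms unchanged, and compound 4 shows no more meaningful displacement than compound 3 does. Nothing in the available data accounts for this flat result.

Going by these compounds, since both compounds sit at the same low level, this pair cannot tell whether the position matters at all, and it remains open whether a phenyl ring carrying an amine or a carboxylic acid in place of the halogens would read any differently. Also open, on these data alone, is whether a plain methyl or a longer chain in place of the neopentyl group, with the 3,4-dichlorophenyl kept, would give a read-out beyond the scatter in this assay at the concentration tested.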